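Swapping a methyl for a nitro on a weak sulfonamide

The source may hold more compounds than are shown below. What is called first, only, known or untested is meant among the compounds shown, and "the series" means these compounds.

Of the compounds shown here, two share a core and have been measured in a functional assay on CFPAC-1 cells (Homo sapiens) for inhibition, read by MTT assay, with a stated time of 72 h; on this read-out lower numbers stand for stronger inhibition and higher numbers for weaker inhibition. Compound 1 `CCCCc1ccc(-c2cn(Cc3cc(=O)oc4cc(O)ccc34)nn2)cc1` gives 69800 nM in this assay. Compound 2 `Cc1ccc(S(=O)(=O)NCc2cn(Cc3cc(=O)oc4cc(O)ccc34)nn2)cc1` gives 68900 nM in this assay. Compound 2 shows the lower of the two numbers, but the two values lie within the scatter of each other, so the data do not separate the two compounds. Among the compounds with values here, no step between these two has been worked out as a single change.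

Compound 3 `O=c1cc(Cn2cc(CNS(=O)(=O)c3ccc([N+](=O)[O-])cc3)nn2)c2ccc(O)cc2o1` is not yet measured. It differs from compound 2 in one place: nitro in place of methyl on an aromatic carbon. In plain words, a nitro sits in place of a methyl on an aromatic carbon.

Within the data shown here, there is no measured step to build on, so the expectation rests only on the weak potency of compound 2 and the smallness of the change. The step from compound 2 to compound 3 is expected to be a 1.1-fold lower number from compound 2 to compound 3 (0.03 log units; within the scatter), which is no change beyond the scatter in either direction. Compound 3 is therefore estimated at 65000 nM in this assay, within a range from 20000 nM to 200000 nM.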

Compound 3, half-maximal inhibitory concentration: > 100000 nM
Compound 3 gave a limit, no number; the forecaster's own chance of this, stated with the estimate: 20%; middle value at least 1.5-fold (0.18 log units) from the limit.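

In this assay, compound 3 gives > 100000 nM, which is a limit of the assay and not a number: the limit of > 100000 nM in this assay, at which 1 of the 3 values shown sits. Read as a step, the change is an at least 1.4-fold higher number from compound 2 to compound 3 (0.16 log units; that floor lies within the scatter), so this floor does not by itself separate the two compounds, and the true size of the difference cannot be read. What the result does add is a first test of this spot on the aromatic ring: going from 4-methylphenyl to 4-nitrophenyl, on a sulfonamide that was already weak, brings no gain in potency, since a gain would have shown up as a measured number lower than that of compound 2.

As far as these compounds go, one swap at one place says little about the position as a whole, so it remains open whether an amine, a carboxylic acid, a methoxy group, a chlorine or a longer chain on this same aromatic carbon would bring the number down. From the compounds shown here alone, it also remains open whether the methyl contributes anything at all, which a plain hydrogen at that carbon would begin to answer.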